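The compounds below may be only part of what the source reports. "The series", "measured", "known", "first", "only" and "open" are said of these compounds alone.

Series notes. Compound 1 `Cc1cc(C(=O)Nc2ccc(N3CC[C@H](N4CCC[C@@H]4C)C3)cc2C)n[nH]1` gives 4.7 nM in an assay on CHO cells for displacement of a labelled ligand from histamine receptor H3 (Macaca mulatta), read by scintillation counting, with a stated time of 1 h; a lower number here means a stronger inhibitor, a higher number a weaker inhibitor. Compound 2 `Cc1nc(N2CC[C@H](N3CCC[C@@H]3C)C2)ccc1NC(=O)c1ccccc1` gives 3 nM in this assay. Compound 1 has the higher of the two numbers, but its gap to compound 2 lies within the usual scatter, so the two are not separated by these data. Compound 3 `Cc1cc(C(=O)Nc2ccc(N3CC[C@H](N4CCC[C@@H]4C)C3)cc2C)on1` is not yet measured in this assay. It differs from compound 1 in one place: 3-methyl-1,2-oxazol-5-yl in place of 5-methyl-1H-pyrazol-3-yl on a carbonyl carbon. Among the measured compounds shown here, no measured pair shows this exchange, so the size of the step has no precedent here, and the only anchor is compound 1 at 4.7 nM. The expectation for compound 3 is a small rise in the number, at the edge of the scatter rather than well beyond it. Compound 3 is therefore expected near 9 nM, with a range from 3 nM to 30 nM. The expected step from compound 1 is a 1.9-fold higher number from compound 1 to compound 3 (0.28 log units; within the scatter).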

Compound 3, inhibition constant in the histamine receptor H3 assay: 1.1 nM
Estimate against measurement, compound 3: 8.2-fold (0.91 log units) above; measured number outside the range, below it.
By their numbers in the histamine receptor H3 assay, from the lowest: compound 3; then compounds 2 and 1 (each within the scatter of the next).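

At this position on a carbonyl carbon, the ring is not interchangeable: in the histamine receptor H3 assay, 3-methyl-1,2-oxazol-5-yl in place of 5-methyl-1H-pyrazol-3-yl gives a 4.3-fold lower number from compound 1 to compound 3 (0.63 log units; beyond the scatter). The entering ring has 0 hydrogen-bond donors against 1 in the leaving ring, so a donor on this ring is not required for a low number in the histamine receptor H3 assay. In a physicochemical assay for acid dissociation, compound 1 gives 12.1 and compound 3 gives 10.1. The same exchange also changes how readily a proton is given up in the physicochemical assay: the measured acid dissociation constant of compound 1, 12.1, and of compound 3, 10.1, a number 2.00 log units lower (beyond the scatter)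

A single pair cannot separate the donor count, the acid dissociation constant and the change of ring atoms as sources of the lower number in the histamine receptor H3 assay. Also open, on these data alone, is what a pyrazole with a methyl group on its ring nitrogen, or a thiazole, would give on this carbonyl carbon.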